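A few compounds are considered here, and "the series" means these few. Any claim that something is new, unique, unknown or untested is made for them only; others in the source may bear on it.

Measured compounds:
Compound 1, `O=C(NCCCCc1ccccc1)c1cccc(C2SCC(=O)N2c2cccc(F)c2)c1`: 94%
Compound 2, `CC(F)(F)c1cccc(N2C(=O)CSC2c2cccc(C(=O)NCCCCc3ccccc3)c2)c1`: 93%

In a functional assay on HOS-TE85 cells (Homo sapiens) for inhibition, read by CCK-8 assay, with a stated time of 72 h, tested at 1 uM (a lower number here means less inhibition, a higher number more inhibition at the concentration tested (going by the name of the read-out)), compound 1 gives 94%. In this assay compound 2 gives 93%. Among the compounds with values here, compound 2 is one of only two measured compounds, and its single neighbour is compound 1: the step of a number 1 percentage points lower from compound 1 to compound 2 (within the scatter) leaves the two values indistinguishable, so compound 2 sits alongside compound 1 rather than apart from it.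

Compound 3 is `COc1ccc(N2C(=O)CSC2c2cccc(C(=O)NCCCCc3ccccc3)c2)c(OC)c1`. It differs from compound 2 in that (a group of 10 heavy atoms (8 carbon, 2 oxygen; one six-membered aromatic ring of carbon only) in place of a group of 10 heavy atoms (8 carbon, 2 fluorine; one six-membered aromatic ring of carbon only), on an amide-type nitrogen in a ring). Within the data shown here, only one measured step bears on this change, a number 1 percentage points lower from compound 1 to compound 2 (within the scatter), which swapped one substituent for another on the same aromatic ring without moving the inhibition beyond the scatter. That step shows that the group on this ring can be altered while high inhibition is kept, but it involved a far smaller change than the one now made, so the expectation is less secure. On that basis a step of a number 5 percentage points lower from compound 2 to compound 3 (within the scatter) is expected, one that may not exceed the scatter. Compound 3 is estimated at 88%, within a range from 68% to 97%.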

Compound 3, a percentage reported as inhibition, at one concentration (the size of the read-out at that concentration, not a potency): 58%
The estimate for compound 3 lay 30 percentage points above the measured number, and the stated range ends above it.
By their numbers in this assay, from the lowest: compound 3; then compounds 2 and 1 (each within the scatter of the next).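

In this assay, the group on the amide-type nitrogen of the five-membered ring proves not to be freely exchangeable: 2,4-dimethoxyphenyl brings a number 35 percentage points lower from compound 2 to compound 3 (beyond the scatter) and, set against 3-fluorophenyl, a number 36 percentage points lower from compound 1 to compound 3 (beyond the scatter) on the shared core. Compound 1 and compound 2, whose values lie within the scatter of each other, had shown only that two substituted rings at this position read alike, whereas compound 3 shows that inhibition here depends on what the ring carries, even though the entering and leaving groups match in heavy-atom count and differ in their hydrogen-bond acceptors and in oxygen against fluorine. No measurement at hand speaks to the cause of this loss.

From the compounds shown here alone, whether the loss requires both methoxy groups of compound 3 or follows from one of them alone stays open, as does how a ring bearing a single methoxy, a hydroxyl or an amine would read. Also open, going by these compounds, is whether this position stays as sensitive when the chain on the amide, the same in all three compounds, is replaced by a shorter chain.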